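Methoxy in Place of Fluoro: What to Expect

A few compounds are considered here, and "the series" means these few. Any claim that something is new, unique, unknown or untested is made for them only; others in the source may bear on it.

Measured so far:
- compound 1 `Fc1ccc(-c2csc(N/N=C/c3ccc(Cl)cc3Cl)n2)cc1` gives 94.6%
- compound 2 `Fc1ccc(-c2csc(N/N=C/c3cccs3)n2)cc1` gives 94.6%

Both values come from a functional assay, read by spectrophotometry, with a stated time of 15 min, tested at 60 ug/mL; a higher number here means a stronger effect of the compound at the concentration tested, a lower number a weaker effect. In this assay compound 1 gives 94.6%, and compound 2 gives 94.6%; compound 1 is level with compound 2 at the digits shown, and the two lie within the scatter. For the measured compounds named here, no step between measured compounds that differ in a single place is known, so nothing measured yet tells how a change on this ring moves the read-out.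

Compound 3 `COc1ccc(-c2csc(N/N=C/c3ccc(Cl)cc3Cl)n2)cc1` differs from compound 1 in one place: methoxy in place of fluoro on an aromatic carbon.

Both measured compounds sit close to the top of the scale, which leaves little room for a rise; the step from compound 1 to compound 3 is expected to be none beyond the scatter, a number 4.6 percentage points lower from compound 1 to compound 3 (within the scatter). Compound 3 is therefore expected to give about 90% in this assay, in a range of 72% to 98%.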

Compound 3, a percentage reported as inhibition, at one concentration (the size of the read-out at that concentration, not a potency): 86.9%
Estimate against measurement, compound 3: 3.1 percentage points above; the range from low to high includes it.
By their numbers in this assay, from the lowest: compounds 3, 1 and 2 (each within the scatter of the next).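

For the compounds shown here, replacing fluoro with methoxy gives a number 7.7 percentage points lower from compound 1 to compound 3 (within the scatter) in this assay and is the first direct reading of a change at this position, on an aromatic carbon para to a large group. The swap adds a heavy atom and a hydrogen-bond acceptor, yet with the rest of compound 1 held fixed the read-out does not move beyond the scatter, so at this one tested concentration the position accepts this change. Nothing available explains this result, and no reason for it can be given.

From the compounds shown here alone, it remains open whether an amine, a carboxylic acid or a longer chain would be accepted at this position as well. Going by these compounds, it is also open whether the same swap on compound 2 would give a similar step.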